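This account rests on a few compounds, and the source may have more. Where it says the series, first, only, none or still open, it means among the compounds named here.

Measured so far in a functional assay on IMR-32 cells (Homo sapiens) for cytotoxicity, read by sulforhodamine B assay, with a stated time of 48 h; on this read-out lower numbers stand for stronger inhibition and higher numbers for weaker inhibition:
Compound 1, `O=CCN1N=C(c2ccc3ccccc3c2)CC1c1cccc(Cl)c1Cl`: 16900 nM
Compound 2, `O=CCN1N=C(c2ccc3ccccc3c2)CC1c1cccc(Br)c1`: 9870 nM
Compound 3, `O=CCN1N=C(c2ccc3ccccc3c2)CC1c1ccco1`: 11000 nM

All three compounds share the same core and differ only in the group attached to one saturated ring carbon. Compound 3 sits close to both of the others: its nearest neighbour is compound 2, with a 1.1-fold higher number from compound 2 to compound 3 (0.05 log units; within the scatter), and its furthest is compound 1, with a 1.5-fold lower number from compound 1 to compound 3 (0.19 log units; within the scatter). Both gaps lie within the scatter of this assay, so the three numbers cannot be told apart with confidence.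

Compound 4, `O=CCN1N=C(c2ccc3ccccc3c2)CC1/C=C/c1ccccc1`, is the next compound to be tested. It differs from compound 3 in one place: 2-phenylethenyl in place of furan-2-yl on a saturated ring carbon. Among the measured compounds shown here, no measured pair covers this exact exchange. What the measured steps do show is that swapping the group at this ring carbon has so far changed little: a 1.7-fold lower number from compound 1 to compound 2 (0.23 log units; within the scatter), a 1.5-fold lower number from compound 1 to compound 3 (0.19 log units; within the scatter) and a 1.1-fold higher number from compound 2 to compound 3 (0.05 log units; within the scatter) all stay within the scatter. Because a 1.1-fold higher number from compound 2 to compound 3 (0.05 log units; within the scatter) stays within the scatter, no step beyond the scatter is expected for compound 4 either, and the expected step is no change at the digits printed from compound 3 to compound 4 (within the scatter). Compound 4 is therefore expected to give about 11000 nM in this assay, with a likely range from 4000 nM to 30000 nM.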

Compound 4, half-maximal inhibitory concentration: 17200 nM
Compound 4: the middle estimate sits 1.6-fold (0.19 log units) below what was measured, and the stated range covers the measured number.
By their numbers in this assay, from the lowest: compounds 2, 3, 1 and 4 (each within the scatter of the next).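

Until now, every group on this saturated ring carbon was an aromatic ring bonded directly to it, whereas in compound 4 the six-membered aromatic ring of 2-phenylethenyl is reached through a double bond outside aromatic rings. Even with this different attachment, and with 8 heavy atoms in place of the 5 of furan-2-yl, the results in this assay stay within the scatter of all three earlier compounds (a 1.6-fold higher number from compound 3 to compound 4 (0.19 log units; within the scatter); a 1.7-fold higher number from compound 2 to compound 4 (0.24 log units; within the scatter); a 1.0-fold higher number from compound 1 to compound 4 (0.01 log units; within the scatter)), so the four groups cannot be ranked and the insensitivity seen so far now extends to a group with a double bond outside aromatic rings. Nothing available here offers an explanation for how close these numbers lie.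

From the compounds shown here alone, all four compounds keep the formylmethyl group and the rest of the shared core, so it remains open whether a change elsewhere, for instance replacing the formylmethyl group with a carboxylic acid, would produce a step beyond the scatter. Going by these compounds, it also remains open whether an amine or a saturated alkyl chain on this ring carbon would stay within the scatter as these aromatic groups do.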